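The source may report more compounds than this note shows. Statements on the series, on what has been measured and on what is new or still open speak of the compounds shown alone.

In a functional assay on J82 cells (Homo sapiens) for cytotoxicity, read by colorimetric assay and MTT assay (on this read-out higher numbers stand for weaker inhibition and lower numbers for stronger inhibition), compound 1 (`COc1ccc(-c2cc3c(OC)cc(OC)cc3n(CC#N)c2=O)cc1`) gives 10000 nM, compound 2 (`COC(=O)CCn1c(=O)c(-c2ccc(OC)cc2)cc2c(OC)cc(OC)cc21`) gives 10000 nM and compound 3 (`COc1ccc(-c2cc3c(OC)cc(OC)cc3n(CCC#N)c2=O)cc1`) gives 10000 nM, so compound 3 stands level with both. Compound 4 (`CCN(CC)C(=O)CCn1c(=O)c(-c2ccc(OC)cc2)cc2c(OC)cc(OC)cc21`) carries diethylcarbamoyl in place of cyano on a saturated chain carbon, two bonds along the chain from an aromatic nitrogen. The measured steps on this chain show no change at the digits printed from compound 1 to compound 2 (within the scatter), no change at the digits printed from compound 1 to compound 3 (within the scatter) and no change at the digits printed from compound 2 to compound 3 (within the scatter). Within the data shown here, no compound with diethylcarbamoyl has been measured yet. Because of no change at the digits printed from compound 2 to compound 3 (within the scatter) no step beyond the scatter is expected in this assay, in either direction. The estimated step is no change at the digits printed from compound 3 to compound 4 (within the scatter). The expected value for compound 4 is 10000 nM, within an estimated range of 4000 nM to 20000 nM.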

Compound 4, half-maximal inhibitory concentration: 10000 nM
For compound 4 middle estimate and measured number coincide at the digits printed; the range from low to high includes it.
By their numbers in this assay, from the lowest: compounds 1, 2, 3 and 4 (each within the scatter of the next).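

In this assay, diethylcarbamoyl in place of cyano gives no change at the digits printed from compound 3 to compound 4 (within the scatter), diethylamino in place of methoxy on a carbonyl carbon gives no change at the digits printed from compound 2 to compound 4 (within the scatter), and (diethylcarbamoyl)methyl in place of cyano gives no change at the digits printed from compound 1 to compound 4 (within the scatter). The series on the aromatic nitrogen thus extends from nitrile and ester ends to an amide end carrying two ethyl groups, and the read-out stays flat. No evidence is available to explain this. From the compounds shown here alone, whether a primary amine or a carboxylic acid at the end of this chain would shift the value remains open.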